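Aryl replacement at the shared core, compound 2 to compound 3

The source may hold more compounds than are shown below. What is called first, only, known or untested is meant among the compounds shown, and "the series" means these compounds.

Among the compounds with values here, compound 2 `CCOC(=O)c1cnc(-c2ccncc2)nc1NN1C(=O)C=C(C)C1=O` gives 6000 nM in a functional assay on Jurkat cells for inhibition of nuclear factor NF-kappa-B complex (Homo sapiens) (a higher number here means a weaker inhibitor, a lower number a stronger inhibitor), the highest of the two numbers measured so far. The nearest is compound 1 `CCOC(=O)c1cnc(C(C)(C)C)nc1NN1C(=O)C=C(C)C1=O`, which in this assay gives 1000 nM. Within the data shown here, the only measured step, a 6.0-fold higher number from compound 1 to compound 2 (0.78 log units; beyond the scatter), came with pyridin-4-yl in place of tert-butyl on an aromatic carbon. Compound 3 `CCOC(=O)c1cnc(-c2ccc(OC)cc2)nc1NN1C(=O)C=C(C)C1=O` carries the change (4-methoxyphenyl in place of pyridin-4-yl on an aromatic carbon), on an aromatic carbon of a six-membered aromatic ring with 2 nitrogen, between two ring nitrogen atoms. Among the measured compounds shown here, no measured step swaps one aromatic group for another at this carbon; the step of a 6.0-fold higher number from compound 1 to compound 2 (0.78 log units; beyond the scatter) shows only that what sits on this carbon moves the number beyond the scatter, so the direction for compound 3 is open and the range must be wide. Compound 3 is expected at about 3000 nM in this assay, within 800 nM to 12000 nM, an estimated step of a 2.0-fold lower number from compound 2 to compound 3 (0.30 log units; within the scatter).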

Compound 3, half-maximal inhibitory concentration: 900 nM
Compound 3: middle estimate off by 3.3-fold (0.52 log units), on the high side; the range from low to high includes it.
By their numbers in this assay, from the lowest: compounds 3 and 1 (each within the scatter of the next); then compound 2.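

In this assay, the exchange of one aromatic group for another on this carbon moves the number beyond the scatter: 4-methoxyphenyl in place of pyridin-4-yl gives a 6.7-fold lower number from compound 2 to compound 3 (0.82 log units; beyond the scatter). An aromatic group here therefore does not by itself go with the weaker number of compound 2, and 4-methoxyphenyl in place of tert-butyl gives a 1.1-fold lower number from compound 1 to compound 3 (0.05 log units; within the scatter), so compound 1 and compound 3 cannot be told apart in this assay. No measurement at hand accounts for the gap between the two aromatic groups.

Still open, as far as these compounds go, is whether the ring nitrogen of pyridin-4-yl or the methoxy group of 4-methoxyphenyl goes with this step, a question that plain phenyl on this carbon would help to separate. Also open, from the compounds shown here alone, is how the number responds to an amine such as morpholine on this carbon, or to a carboxylic acid in place of the ethoxycarbonyl group.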